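Swapping 3-nitrophenyl for furan-2-yl on a carbonyl carbon

The source may report more compounds than this note shows. Statements on the series, on what has been measured and on what is new or still open speak of the compounds shown alone.

Three compounds sharing one core have numbers in a functional assay on MCF7 cells (Homo sapiens) for antiproliferative activity, read by MTT assay, with a stated time of 72 h; on this read-out higher numbers stand for weaker inhibition and lower numbers for stronger inhibition. Compound 1 `CC(=O)O[C@H]1CC[C@]2(C)[C@H](CC[C@@](C)(O)[C@H]2CC[C@@H]2C(C)=CC[C@H]3[C@H](CC[C@]3(C)O)C2(C)C)OC1(C)C` gives 47900 nM, compound 2 `CC1=CC[C@H]2[C@H](CC[C@]2(C)O)C(C)(C)[C@@H]1CC[C@H]1[C@]2(C)CC[C@H](OC(=O)c3ccc([N+](=O)[O-])cc3)C(C)(C)O[C@H]2CC[C@@]1(C)O` gives 21600 nM, and compound 3 `CC1=CC[C@H]2[C@H](CC[C@]2(C)O)C(C)(C)[C@@H]1CC[C@H]1[C@]2(C)CC[C@H](OC(=O)c3cccc([N+](=O)[O-])c3)C(C)(C)O[C@H]2CC[C@@]1(C)O` gives 36000 nM. The number for compound 3 lies inside the range set by the other two and cannot be separated from either: a 1.3-fold lower number from compound 1 to compound 3 (0.12 log units; within the scatter) and a 1.7-fold higher number from compound 2 to compound 3 (0.22 log units; within the scatter). For the measured compounds named here, the only step beyond the scatter is a 2.2-fold lower number from compound 1 to compound 2 (0.35 log units; beyond the scatter), and it is modest.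

Compound 4 `CC1=CC[C@H]2[C@H](CC[C@]2(C)O)C(C)(C)[C@@H]1CC[C@H]1[C@]2(C)CC[C@H](OC(=O)c3ccco3)C(C)(C)O[C@H]2CC[C@@]1(C)O` differs from compound 3 by one change: furan-2-yl in place of 3-nitrophenyl on a carbonyl carbon. This puts furan-2-yl in place of 3-nitrophenyl on a carbonyl carbon. Going by the values given here, no measured compound carries furan-2-yl, so the evidence is indirect. Exchanging the group at this place has so far moved the number little, as a 2.2-fold lower number from compound 1 to compound 2 (0.35 log units; beyond the scatter) and a 1.3-fold lower number from compound 1 to compound 3 (0.12 log units; within the scatter) show, so no step beyond the scatter is expected in this assay. The expected step is a 1.1-fold higher number from compound 3 to compound 4 (0.02 log units; within the scatter). Compound 4 is estimated at 38000 nM, with an expected range from 15000 nM to 85000 nM.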

Compound 4, half-maximal inhibitory concentration: 25700 nM
For compound 4 the middle estimate is 1.5-fold (0.17 log units) above the measured one; measured number inside the range.
By their numbers in this assay, from the lowest: compounds 2, 4, 3 and 1 (each within the scatter of the next, the first and the last beyond it).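

In this assay, furan-2-yl, a five-membered aromatic ring, can stand on this carbonyl carbon in place of the six-membered ring of 3-nitrophenyl with no step beyond the scatter: a 1.4-fold lower number from compound 3 to compound 4 (0.15 log units; within the scatter). The same holds against the other two groups at this place, with a 1.2-fold higher number from compound 2 to compound 4 (0.08 log units; within the scatter) and a 1.9-fold lower number from compound 1 to compound 4 (0.27 log units; within the scatter), so a nitro group is not needed to stay in the range of compound 2 and compound 3. Nothing available here explains why the number moves so little with these exchanges.

All four compounds keep the same ester link and differ only in the group on its carbonyl carbon. As far as these compounds go, it remains open whether a phenyl ring bearing an amine or a carboxylic acid, or a longer carbon chain, would move the number further at this place.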